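The source may report more compounds than this note shows. Statements on the series, on what has been measured and on what is new or still open speak of the compounds shown alone.

Compound 1, `CCOC(=O)[C@@]12C[C@@H]1[C@@H](n1cnc3c(NC)nc(C#Cc4ccc(Br)s4)nc31)[C@H](O)[C@@H]2O`: 6.42 nM in an assay on HEK-293T cells for displacement of a labelled ligand from transmembrane domain-containing protein TMIGD3 (Homo sapiens), read by scintillation counting and radioligand binding, with stated times of 10 min and 90 min; a lower number here means a stronger inhibitor, a higher number a weaker inhibitor
Compound 2, `CNc1nc(C#Cc2ccc(Cl)s2)nc2c1ncn2[C@H]1[C@H](O)[C@H](O)[C@]2(C(=O)OC(C)C)C[C@H]12`: 42.9 nM

Of the two measured compounds, compound 2 has the higher number, and the gap to compound 1 lies beyond the scatter. Compound 3, `CNc1nc(C#Cc2ccc(Cl)s2)nc2c1ncn2[C@H]1[C@H](O)[C@H](O)[C@]2(C(=O)OCCC3CCCCC3)C[C@H]12`, keeps the whole of compound 2 except for one change: 2-cyclohexylethyl in place of isopropyl on an oxygen next to a carbonyl group. Going by the values given here, no measured pair shows this change, so the step can only be guessed. A somewhat weaker result is expected for compound 3, with the step of a 1.5-fold higher number from compound 2 to compound 3 (0.18 log units; within the scatter), though a step within the scatter is also plausible. The estimate for compound 3 in this assay is 65 nM, with a likely range from 15 nM to 280 nM.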

Compound 3, inhibition constant: 770 nM
Compound 3: middle estimate off by 12-fold (1.07 log units), on the low side; measured number above the stated range.
By their numbers in this assay, from the lowest: compound 1; then compound 2; then compound 3.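

In this assay, putting 2-cyclohexylethyl in place of isopropyl on an oxygen next to a carbonyl group gives an 18-fold higher number from compound 2 to compound 3 (1.25 log units; beyond the scatter), a step beyond the scatter. This position is therefore not indifferent to what it carries: with the rest of compound 2 unchanged, this one swap alone clearly weakens binding. Nothing available accounts for the size of this step.

On these data alone, whether the ring or the chain matters more remains open, as a straight octyl chain or a cyclohexyl group directly on that oxygen would be needed to separate them. Also open, as far as these compounds go, is how a methyl group or a free carboxylic acid would fare here.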